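The source may hold more compounds than are shown below. What is called first, only, known or untested is meant among the compounds shown, and "the series" means these compounds.

Measured compounds:
compound 1 `O=C(Nc1ccc(Cc2ccccc2)cc1)Nc1nn(C(=O)Nc2ccc(Cc3ccccc3)cc2)c2ccccc12` — > 100000 nM
compound 2 `Nc1nn(C(=O)Nc2ccc(Cc3ccccc3)cc2)c2ccccc12` — 3760 nM

In a functional assay on 786-0 cells (Homo sapiens) for inhibition, read by sulforhodamine B assay, with a stated time of 48 h (on this read-out higher numbers stand for weaker inhibition of growth and lower numbers for stronger inhibition of growth), compound 1 gives > 100000 nM, which is a limit of the assay and not a number. The result for compound 1 is the limit of > 100000 nM in this assay, at which 1 of the 2 values shown sits. Compound 2, in this assay, gives 3760 nM, and this is the only actual number among the two results shown. Compound 2 therefore stands alone as the reference point for what follows.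

Compound 3 `CCCCOc1ccc(NC(=O)n2nc(N)c3ccccc32)cc1` has not yet been measured. It differs from compound 2 in one place: butoxy in place of benzyl on an aromatic carbon. No measured pair among these compounds shows a change of this kind, so nothing here tells how large such a step tends to be.

Compound 3 is expected to give 4000 nM in this assay, with a range from 1000 nM to 16000 nM. The step from compound 2 to compound 3 is thus estimated as a 1.1-fold higher number from compound 2 to compound 3 (0.03 log units; within the scatter), which is not expected to go beyond the usual scatter in either direction.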

Compound 3, concentration for 50% growth inhibition: 21000 nM
Beside the measured number, compound 3's estimate is 5.3-fold (0.72 log units) below it; measured number outside the range, above it.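

In this assay the swap of benzyl for butoxy on this aromatic carbon brings a 5.6-fold higher number from compound 2 to compound 3 (0.75 log units; beyond the scatter), which means weaker inhibition of growth. What sits at this position therefore matters, although compound 3 still gives a real number rather than a limit of the assay. The swap removes a ring and brings in a chain that holds an oxygen, so these two changes travel together and this one step cannot separate them.

Nothing measured here gives a reason for the step. From the compounds shown here alone, it remains open whether a pentyl chain, which has no oxygen, or a phenoxy group, which keeps a ring and adds an oxygen, would stay close to compound 2 or fall away as compound 3 does.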